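A few compounds are considered here, and "the series" means these few. Any claim that something is new, unique, unknown or untested is made for them only; others in the source may bear on it.

Working notes on the series. Compound 1 `O=c1[nH]c(-c2cccc3ccccc23)nc2ccc(N3CCCCC3)cc12` holds the top of the three measured numbers: in an assay on isolated protein for inhibition of DNA topoisomerase 1 (Homo sapiens), with a stated time of 30 min, tested at 100 uM (on this read-out higher numbers stand for a stronger effect at the one concentration tested and lower numbers for a weaker effect), compound 1 gives 100%. Compound 3 `Cc1ccc2nc(-c3ccccc3N(C)C)[nH]c(=O)c2c1` comes nearest; in this assay compound 3 gives 82.9%, a gap beyond the scatter. Compound 2 `Cc1ccc2c(=O)[nH]c(-c3cccc(OC(F)(F)F)c3)nc2c1` lies furthest off; in this assay compound 2 gives 77.2%, again beyond the scatter. Both compound 2 and compound 3 carry methyl on the core where compound 1 carries piperidin-1-yl, and both sit clearly under compound 1, though they also differ from compound 1 in the aryl group, so the two changes cannot be separated on the measured compounds.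

Compound 4 `Cc1ccc2nc(-c3cccc4ccccc34)[nH]c(=O)c2c1` has not been measured. It differs from compound 1 in one place: methyl in place of piperidin-1-yl on an aromatic carbon. Within the data shown here, no measured pair shows this change by itself, so the step in this assay cannot be read off directly. The expectation is a drop beyond the scatter, because compound 2 at 77.2% and compound 3 at 82.9% both carry methyl on the core and both fall well short of compound 1. Compound 4 keeps the aryl group of compound 1, which argues against a drop as deep as those two. The expected step is a number 16 percentage points lower from compound 1 to compound 4 (beyond the scatter). Compound 4 is estimated at 84%, within a range from 66% to 100%.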

Compound 4, a percentage reported as inhibition, at one concentration (the size of the read-out at that concentration, not a potency): 4.1%
The estimate for compound 4 lay 79.9 percentage points above the measured number, and the stated range ends above it.
By their numbers in this assay, from the lowest: compound 4; then compounds 2 and 3 (each within the scatter of the next); then compound 1.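

The change of methyl in place of piperidin-1-yl on an aromatic carbon, with the aryl group of compound 1 kept, gives a number 95.9 percentage points lower from compound 1 to compound 4 (beyond the scatter) in this assay, so the contribution of this position can now be read apart from that of the aryl group. Methyl at this position does not by itself fix a low number, however: in this assay, compound 4 gives 4.1%, whereas compound 3, which keeps the same methyl-bearing core with a different aryl group, gives 82.9%, so the outcome with methyl also depends on the aryl group. No measurement at hand bears on what lies behind the size of the step from piperidin-1-yl to methyl.

Open, going by these compounds, is whether a morpholin-4-yl ring, an open-chain diethylamino group or a plain pentyl chain at this position would stay near compound 1 or fall towards compound 4, which would show whether the ring, its nitrogen or the chain length of the substituent tracks with the read-out. Also open, on these data alone, is whether piperidin-1-yl would give a step of similar size on the core of compound 3, with its dimethylamino-bearing aryl group in place.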